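Compound 1 to compound 4: dipentylamino at the chain end

The source may report more compounds than this note shows. Statements on the series, on what has been measured and on what is new or still open speak of the compounds shown alone.

Measured in a functional assay on PC-3 cells (Homo sapiens) for antiproliferative activity, read by WST assay, with a stated time of 3 days; on this read-out lower numbers stand for stronger inhibition and higher numbers for weaker inhibition
compound 1 `CCCCCCCOc1c(-c2cc(OC)c(OC)c(OC)c2)oc2ccccc2c1=O` gives the limit > 50000 nM
compound 2 `COc1cc(-c2oc3ccccc3c(=O)c2OC(C)C)cc(OC)c1OC` gives 21200 nM
compound 3 `CCCC(C)Oc1c(-c2cc(OC)c(OC)c(OC)c2)oc2ccccc2c1=O` gives 49300 nM

Compound 1 gives only a limit and no number, and it stands at the limit of > 50000 nM in this assay, at which 1 of the 3 values shown sits.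

Compound 4 `CCCCCN(CCCCC)CCCCCOc1c(-c2cc(OC)c(OC)c(OC)c2)oc2ccccc2c1=O` carries dipentylamino in place of ethyl on a saturated chain carbon, five bonds along the chain from an oxygen on an aromatic ring.

The nearest evidence is an at least 2.3-fold lower number from compound 1 to compound 2 (0.37 log units; beyond the scatter), which lies beyond the scatter. The step of an at least 1.0-fold lower number from compound 1 to compound 3 (0.00 log units; that floor lies within the scatter) has a floor within the scatter, and a 2.3-fold higher number from compound 2 to compound 3 (0.37 log units; beyond the scatter) is modest. Among the measured compounds shown here, none of the measured compounds carries dipentylamino, so these steps set the size only loosely. A lower number is expected, resting on compound 2 with an at least 2.3-fold lower number from compound 1 to compound 2 (0.37 log units; beyond the scatter), though a larger step is expected here for the larger change. The expected step in this assay is an at least 5.5-fold lower number from compound 1 to compound 4 (0.74 log units; beyond the scatter). For compound 4 the estimate is 9000 nM, with an expected range of 2500 nM to 32000 nM.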

Compound 4, half-maximal inhibitory concentration: 9600 nM
The estimate for compound 4 lay 1.1-fold (0.03 log units) below the measured number; the range from low to high includes it.
By their numbers in this assay, from the lowest: compound 4; then compound 2; then compound 3. At a limit, above all of these: compound 1.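

In this assay, dipentylamino in place of ethyl on a saturated chain carbon, five bonds along the chain from an oxygen on an aromatic ring, gives an at least 5.2-fold lower number from compound 1 to compound 4 (0.71 log units; beyond the scatter). The earlier lower numbers at this oxygen came with isopropyl or 1-methylbutyl in place of heptyl, whereas here the chain end takes on a group of more heavy atoms and the number still falls, so a lower number at this position does not depend on a smaller group. Compound 1 gives a limit and no number, so this step is a floor and not a size: the limit of > 50000 nM in this assay, at which 1 of the 4 values shown sits.

On these data alone, it remains open whether the nitrogen or the two pentyl groups carry the change. A dimethylamino or morpholine group, or a carboxylic acid, at the same chain end would separate these readings.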